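Swapping Propoxy for Acetamido on the Aryl Piperazine

This account rests on a few compounds, and the source may have more. Where it says the series, first, only, none or still open, it means among the compounds named here.

Three compounds share a core built from a cyclic amide joined through a three-carbon chain to a piperazine carrying a phenyl ring. In an assay on cell membranes for binding affinity to Sigma non-opioid intracellular receptor 1 (Rattus norvegicus) (on this read-out lower numbers stand for stronger inhibition and higher numbers for weaker inhibition), compound 1 `COc1ccc2c(c1)N(CCCN1CCN(c3cccc(Cl)c3)CC1)C(=O)CC2` gives 1130 nM, compound 2 `COc1cccc2c1N(CCCN1CCN(c3cccc(Cl)c3)CC1)C(=O)CC2` gives 600 nM, and compound 3 `CCCOc1cccc(N2CCN(CCCN3C(=O)CCc4c(Cl)cccc43)CC2)c1` gives 370 nM, the lowest of the three, although its gap to compound 2 lies within the scatter. Compound 4 `CC(=O)Nc1cccc(N2CCN(CCCN3C(=O)CCc4c(Cl)cccc43)CC2)c1` differs from compound 3 in one place: acetamido in place of propoxy on an aromatic carbon. Among the compounds with values here, no measured pair shows what such a change does here, so the expectation rests on compound 3 alone. A modest weakening is expected, with the step from compound 3 to compound 4 estimated at a 2.2-fold higher number from compound 3 to compound 4 (0.33 log units; beyond the scatter). Compound 4 is thus expected to give about 800 nM, somewhere between 250 nM and 2500 nM.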

Compound 4, half-maximal inhibitory concentration: 670 nM
The estimate for compound 4 lay 1.2-fold (0.08 log units) above the measured number, and the stated range covers the measured number.
By their numbers in this assay, from the lowest: compounds 3, 2, 4 and 1 (each within the scatter of the next, the first and the last beyond it).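

Acetamido in place of propoxy on this aromatic carbon gives a 1.8-fold higher number from compound 3 to compound 4 (0.26 log units; within the scatter) in this assay, so the two groups cannot be told apart on this read-out. This position therefore accepts a swap that brings in a hydrogen-bond donor without a change beyond the usual scatter. Nothing shown offers a reason for this result.

Going by these compounds, it remains open whether an amine, a carboxylic acid or a longer chain at this position would also stay within the scatter. On these data alone, it is also open whether this swap would behave the same way on a different core.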